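The source may report more compounds than this note shows. Statements on the series, on what has been measured and on what is new or still open speak of the compounds shown alone.

Among the compounds with values here, compound 1, `ClCc1ccc(Cn2cnc3c(Cl)ncnc32)cc1`, stands at the top of the three numbers so far. In a functional assay on SK-MEL-5 cells (Homo sapiens) for cytotoxicity, read by sulforhodamine B assay, with a stated time of 48 h (on this read-out lower numbers stand for stronger inhibition of growth and higher numbers for weaker inhibition of growth), compound 1 gives 20900 nM, the highest figure in the set. Compound 2, `ClCc1cccc(Cn2cnc3nc(Cl)nc(Cl)c32)c1`, gives 2450 nM in this assay, and compound 3, `ClCc1ccccc1Cn1cnc2nc(Cl)nc(Cl)c21`, gives 2180 nM; both of them sit beyond the scatter below compound 1, with compound 2 the nearer and compound 3 the further.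

The next compound is compound 4, `ClCc1ccc(Cn2cnc3c(Cl)nc(Cl)nc32)cc1`, which is reached from compound 1 by a single change: chloro in place of hydrogen on an aromatic carbon. Within the data shown here, no measured pair in the set shows this exact step, so its size can only be estimated.

The account expects compound 4 to move to a lower number than compound 1, by a step of roughly the size that separates compound 1 from compound 2 and compound 3, since among the other compounds in this assay that carry a chloro at this place compound 2 gives 2450 nM and compound 3 gives 2180 nM. Compound 4 is therefore estimated at 4000 nM, with a range from 1500 nM to 12000 nM, the step being expected as a 5.2-fold lower number from compound 1 to compound 4 (0.72 log units; beyond the scatter), beyond the scatter.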

Compound 4, concentration for total growth inhibition: 19100 nM
For compound 4 the middle estimate is 4.8-fold (0.68 log units) below the measured one; the whole stated range lies below it.
By their numbers in this assay, from the lowest: compounds 3 and 2 (each within the scatter of the next); then compounds 4 and 1 (each within the scatter of the next).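

Chloro in place of hydrogen on this aromatic carbon, between two ring nitrogen atoms, gives a 1.1-fold lower number from compound 1 to compound 4 (0.04 log units; within the scatter) in this assay; on this core, the added chloro therefore brings no difference that can be told from the scatter. Within the data shown here, this is the first direct reading of the position, since compounds 2 and 3 each differ from compound 4 in more than one place and their steps to it cannot be read, so their printed numbers say nothing about this chloro taken alone. Nothing in the data shown explains why this chloro leaves the read-out within the scatter.

From the compounds shown here alone, what stays open is whether another group on this same carbon, such as an amine, a methoxy group or a longer chain, would give a step beyond the scatter where chloro does not. Going by these compounds, it is also open whether chloro in place of hydrogen at this position would give a step of the same size on the cores of compound 2 and compound 3, where the chloromethyl group and the ring attachment differ.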